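Triazole side chains on the shared core: decyl next

This account rests on a few compounds, and the source may have more. Where it says the series, first, only, none or still open, it means among the compounds named here.

Compound 1 `O=C1O[C@H]([C@@H](O)Cn2cc(-c3ccc(Br)cc3)nn2)C(OCc2ccccc2)=C1OCc1ccccc1`: 5070 nM in a functional assay on HepG2 cells (Homo sapiens) for antiproliferative activity, read by MTT assay, with a stated time of 72 h; on this read-out higher numbers stand for weaker inhibition and lower numbers for stronger inhibition.
Compound 2 `O=C1O[C@H]([C@@H](O)Cn2cc(-c3cc(C(F)(F)F)cc(C(F)(F)F)c3)nn2)C(OCc2ccccc2)=C1OCc1ccccc1`: 33800 nM.
Compound 3 `CC(C)(C)OC(=O)N1CCN(C(=S)SCc2cn(C[C@H](O)[C@H]3OC(=O)C(OCc4ccccc4)=C3OCc3ccccc3)nn2)CC1`: > 100000 nM, which is a limit of the assay and not a number.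

Among the two numbers shown, compound 1 holds the lowest; compound 2 gives the higher one, and the gap between them lies beyond the scatter. Compound 3 gives only a limit (the limit of > 100000 nM in this assay, at which 1 of the 3 values shown sits). Compound 4 `CCCCCCCCCCc1cn(C[C@H](O)[C@H]2OC(=O)C(OCc3ccccc3)=C2OCc2ccccc2)nn1` differs from compound 1 by decyl in place of 4-bromophenyl on an aromatic carbon. Among the compounds with values here, no step between measured compounds differing in one place is available, so no size for such a change can be read from the data. Compound 4 is expected at 4000 nM, within a range from 800 nM to 20000 nM. The expected step is a 1.3-fold lower number from compound 1 to compound 4 (0.10 log units; within the scatter), estimated as none beyond the scatter.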

Compound 4, half-maximal inhibitory concentration: 12200 nM
Compound 4: the middle estimate sits 3.1-fold (0.48 log units) below what was measured; measured number inside the range.
By their numbers in this assay, from the lowest: compound 1; then compound 4; then compound 2. At a limit, above all of these: compound 3.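

Decyl in place of 4-bromophenyl on an aromatic carbon brings a 2.4-fold higher number from compound 1 to compound 4 (0.38 log units; beyond the scatter) in this assay, the first size available for a change at this place. The step is modest: with no ring in the entering group, compound 4 still gives a number and not a limit, so an aromatic ring at this place is not needed for a measurable value. No measured property bears on this step, so it carries no explanation. The compounds shown leave open how a shorter chain such as hexyl, or a decyl chain ending in an amine or a carboxylic acid, would move the number at this place.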